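A few compounds are considered here, and "the series" means these few. Any claim that something is new, unique, unknown or untested is made for them only; others in the source may bear on it.

Of the compounds shown here, three built on one shared core have been measured in a functional assay on the whole organism (strain albino) for inhibition, with Rattus norvegicus as the target, read by paw edema, with a stated time of 120 min, at a dose of 100 mg/kg by the oral route; a lower number here means less inhibition, a higher number more inhibition at the dose given (going by the name of the read-out). Compound 1, `Clc1ccccc1NCc1nc2ccc(Br)cc2[nH]1`, gives 23.5%. Compound 2, `Brc1ccc(NCc2nc3ccc(Br)cc3[nH]2)cc1`, gives 23.5%. Compound 3, `COc1ccc(NCc2nc3ccccc3[nH]2)cc1`, gives 29.4%. Compound 2 therefore matches compound 1 at the digits shown, and the number for compound 3 differs from it by an amount that lies within the usual scatter of this kind of measurement, so none of the three can be told apart with any confidence.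

Compound 4, `Cc1ccc(NCc2nc3ccc(Br)cc3[nH]2)cc1`, has not yet been measured in this assay. It differs from compound 2 in a single place: methyl in place of bromo on an aromatic carbon. Going by the values given here, no pair of measured compounds differing in only one place is available, so nothing on hand shows what this exchange does to the read-out; compound 2 and compound 3 differ in two places at once and their numbers lie within the scatter. Given that all three measured numbers sit within the scatter of one another, the change is expected to produce no step beyond the scatter in either direction, and a number 1.5 percentage points higher from compound 2 to compound 4 (within the scatter) is estimated to be small. For compound 4 in this assay the expected value is 25%, within a range from 12% to 38%. That expectation rests on compound 2, whose result of 23.5% is the closest point of reference.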

Compound 4, a percentage reported as inhibition, in the whole organism at one dose (the size of the read-out at that dose, not a potency): 23.5%
Compound 4: the middle estimate sits 1.5 percentage points above what was measured; low and high end bracket the measured number.
By their numbers in this assay, from the lowest: compounds 1, 2, 4 and 3 (each within the scatter of the next).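

Replacing bromo with methyl on this aromatic carbon, para to a large group, gives no change at the digits printed from compound 2 to compound 4 (within the scatter) in this assay. Going by these compounds alone, this is the first comparison in the set in which only one place differs, so the exchange can now be read alone rather than inferred from compounds that differ in more than one place, and at this single oral dose the read-out does not separate the two groups. Nothing available explains this result or shows whether the two compounds would still match at another dose or time.

The compounds shown leave open whether a very different group at this same position, such as an amine, a carboxylic acid or a longer chain, would produce a step beyond the scatter. They also leave open what the bromo on the shared core contributes, as compound 3 differs from compound 2 in two places at once and its number cannot be assigned to either change.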